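The compounds below may be only part of what the source reports. "The series", "measured", "known", "first", "only" and "open" are said of these compounds alone.

Measured so far:

Compound 1 `Nc1nc(N/N=C/c2cccc(OCc3ccccc3)c2)nc2c1ncn2[C@@H]1O[C@H](CO)[C@@H](O)[C@H]1O` — 13 nM
Compound 2 `Nc1nc(N/N=C/c2ccc(OCc3ccccc3)c(OCc3ccccc3)c2)nc2c1ncn2[C@@H]1O[C@H](CO)[C@@H](O)[C@H]1O` — > 10000 nM

The study compares two hydrazone nucleosides in an assay on CHO-K1 cells for displacement of a labelled ligand from adenosine receptor A1 (Homo sapiens), read by scintillation counting, with a stated time of 60 min; on this read-out lower numbers stand for stronger inhibition and higher numbers for weaker inhibition. Compound 1 gives 13 nM in this assay. For compound 2 this assay gives only a limit, > 10000 nM, so no number is known for it. The step of an at least 760-fold higher number from compound 1 to compound 2 (2.88 log units; beyond the scatter) is therefore only a lower bound, and compound 2 stands at the weak end of what this assay reports (the limit of > 10000 nM in this assay, at which 1 of the 2 values shown sits).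

Compound 3 `COc1cc(/C=N/Nc2nc(N)c3ncn([C@@H]4O[C@H](CO)[C@@H](O)[C@H]4O)c3n2)ccc1OCc1ccccc1` has not yet been measured in this assay. It differs from compound 2 by hydrogen in place of phenyl on a saturated chain carbon bound to an oxygen on an aromatic ring. This undoes part of the change that separates compound 1 from compound 2, but it does not recreate compound 1: a methoxy and a benzyloxy remain on the ring. Among the measured compounds shown here, the only measured step that bears on it is an at least 760-fold higher number from compound 1 to compound 2 (2.88 log units; beyond the scatter), which shows that adding a benzyloxy to compound 1 removed binding beyond the limit of this assay. Removing the phenyl from one benzyloxy of compound 2 is expected to move the number back down, by a step of roughly an at least 6.6-fold lower number from compound 2 to compound 3 (0.82 log units; beyond the scatter). Compound 3 is accordingly estimated at 1500 nM, in a range from 150 nM to 10000 nM.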

Compound 3, inhibition constant: 9140 nM
Beside the measured number, compound 3's estimate is 6.1-fold (0.78 log units) below it, and the stated range covers the measured number.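

In this assay, among the compounds shown here, compound 3 gives 9140 nM, the first true number on a ring that carries two oxygen substituents, and it shows that a methoxy paired with a benzyloxy still leaves the number towards the weak end of what is reported here. The change from benzyloxy to methoxy reads as an at least 1.0-fold lower number from compound 2 to compound 3 (0.03 log units; that floor lies within the scatter), so removing this phenyl is not shown to have moved the number, nor is it shown to have left it unmoved. The true size of this step stays unknown because compound 2 has only a limit: the limit of > 10000 nM in this assay, at which 1 of the 3 values shown sits.

The compounds shown leave open whether a hydroxyl, an ethoxy or a fluorine in place of the methoxy would give a different number in this assay. For the compounds shown here, they also leave open how much of the loss seen with the second substituent depends on that group's identity and how much on its place on the ring, since compound 3 keeps a substituent there and carries its benzyloxy in a different arrangement from the one in compound 1.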